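A few compounds are considered here, and "the series" means these few. Any claim that something is new, unique, unknown or untested is made for them only; others in the source may bear on it.

Working notes on the series. In a functional assay (QGY7701 cells, Homo sapiens) for inhibition, read by MTT assay, with a stated time of 48 h (on this read-out higher numbers stand for weaker inhibition and lower numbers for stronger inhibition), compound 1 (`O=C(/C=C/c1coc2cc(O)ccc2c1=O)NCc1ccccc1`) gives 63000 nM and compound 2 (`COc1ccc2c(=O)c(/C=C/C(=O)NCc3ccc(F)cc3)coc2c1`) gives 7960 nM. Compound 2 thus holds the lower of the two numbers, and the gap is beyond the scatter. The two compounds differ in more than one place, so that gap cannot be assigned to any single change. Compound 3 (`O=C(/C=C/c1coc2cc(O)ccc2c1=O)NCc1ccc(F)cc1`) departs from compound 2 in one place: hydrogen in place of methyl on an oxygen on an aromatic ring, or methoxy to hydroxy. Among the measured compounds shown here, the only measured hydroxy compound, compound 1 at 63000 nM, sits higher, so weaker inhibition is expected. The expected change in this assay is a 3.8-fold higher number from compound 2 to compound 3 (0.58 log units; beyond the scatter), a rise beyond the scatter. For compound 3 the estimated value is 30000 nM, with an expected range of 10000 nM to 90000 nM.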

Compound 3, half-maximal inhibitory concentration: > 100000 nM
Compound 3: no number, only a limit; the forecaster's own chance of this, stated with the estimate: 5%; middle value at least 3.3-fold (0.52 log units) from the limit.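

Methoxy to hydroxy on this aromatic ring can now be read as a single change, and it gives a large step: an at least 12-fold higher number from compound 2 to compound 3 (1.09 log units; beyond the scatter). In this assay, on these data alone, compound 3 gives only a limit, not a number, so the step is a floor and its true size remains unknown: the limit of > 100000 nM in this assay, at which 1 of the 3 values shown sits. With fluoro in place of hydrogen on an aromatic carbon, the step is an at least 1.5-fold higher number from compound 1 to compound 3 (0.20 log units; that floor lies within the scatter); that floor lies within the scatter, so it sets no order between these two compounds and gives no effect for fluoro.

The compounds shown give no cause for the methoxy to hydroxy step, and they do not show whether it would have the same size without the fluoro. As far as these compounds go, whether an ethoxy group or an amine in place of methoxy would stay near compound 2 also remains open.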